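Replacing 2-hydroxy-5-methylphenyl with 3-(trifluoromethyl)phenyl

The source may report more compounds than this note shows. Statements on the series, on what has been measured and on what is new or still open speak of the compounds shown alone.

Compound 1 `COc1cc(CNc2ncnc3c2ncn3[C@@H]2O[C@H](CO)[C@@H](O)[C@H]2O)cc(OC)c1`: "not determined" (no result reported)
Compound 2 `Cc1ccc(O)c(CNc2ncnc3c2ncn3[C@@H]2O[C@H](CO)[C@@H](O)[C@H]2O)c1`: > 166000 nM

The two compounds share a core and were taken into a functional assay on G-361 cells (Homo sapiens) for antiproliferative activity, with a stated time of 72 h (a higher number here means a weaker inhibitor, a lower number a stronger inhibitor), but they give no number to work from. Compound 1 has no reported result, so it offers no comparison. Compound 2 gives > 166000 nM in this assay, and this is a limit of the assay, not a number.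

The next compound is compound 3 `OC[C@H]1O[C@@H](n2cnc3c(NCc4cccc(C(F)(F)F)c4)ncnc32)[C@H](O)[C@@H]1O`, which keeps the shared core and changes one group. It carries 3-(trifluoromethyl)phenyl in place of 2-hydroxy-5-methylphenyl, on a saturated chain carbon bound to a nitrogen on an aromatic ring (3-(trifluoromethyl)phenyl in place of 2-hydroxy-5-methylphenyl on a saturated chain carbon bound to a nitrogen on an aromatic ring).

Among the measured compounds shown here, no measured step shows what such a change does in this assay. Since the entry for compound 2 is > 166000 nM, a limit, any number reported for compound 3 is expected on the stronger side. A step beyond the scatter is expected if a number appears at all, though another limit remains possible. The estimated change is an at least 5.5-fold lower number from compound 2 to compound 3 (0.74 log units; beyond the scatter). Compound 3 is expected at 30000 nM, with an estimated range of 3000 nM to 166000 nM.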

Compound 3, half-maximal inhibitory concentration: > 166000 nM
Compound 3 was reported as a limit; the forecaster's own chance of this, stated with the estimate: 35%; middle value at least 5.5-fold (0.74 log units) from the limit.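

In this assay, no step can be read from compound 2 to compound 3, because each entry is a limit of the assay and not a number: the limit of > 166000 nM in this assay, at which 2 of the 3 values shown sit.

The compounds shown leave open how far 2-hydroxy-5-methylphenyl and 3-(trifluoromethyl)phenyl differ in this read-out, and where compound 1 stands relative to them.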